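Benzylic ether series: cytotoxicity on Vero cells

The source may hold more compounds than are shown below. What is called first, only, known or untested is meant among the compounds shown, and "the series" means these compounds.

Compound 2 `COCCOCOc1ccc2c(c1)[C@@H](O)CN(C)C2` carries a 2-methoxyethoxy group on the shared core. In an ADME assay on Vero cells (Chlorocebus sabaeus) for cytotoxicity, read by sulforhodamine B assay, with a stated time of 72 h (on this read-out higher numbers stand for weaker inhibition and lower numbers for stronger inhibition), compound 2 reaches only the limit > 50000 nM, not a number. Compound 1 `CN1Cc2ccc(OCC3CCCCC3)cc2[C@@H](O)C1` gives 65600 nM in this assay. Compound 3 `CN1Cc2ccc(OCc3cccc(Br)c3)cc2[C@@H](O)C1` differs from compound 2 by 3-bromophenyl in place of 2-methoxyethoxy on a saturated chain carbon bound to an oxygen on an aromatic ring. Among the compounds with values here, the only measured step, a step that the limit leaves unreadable from compound 1 to compound 2, bears on this change, and its size is hidden by the limit of > 50000 nM in this assay, at which 1 of the 2 values shown sits. No readable step guides the expectation for compound 3 in this assay. The expected step of a number no higher from compound 2 to compound 3 (the limit leaves the size open) is taken as no change beyond the scatter. Compound 3 is estimated at 50000 nM, between 20000 nM and 150000 nM.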

Compound 3, half-maximal inhibitory concentration: 60300 nM
Beside the measured number, compound 3's estimate is 1.2-fold (0.08 log units) below it; low and high end bracket the measured number.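

In this assay, within the data shown here, 3-bromophenyl in place of cyclohexyl on a saturated chain carbon bound to an oxygen on an aromatic ring gives a 1.1-fold lower number from compound 1 to compound 3 (0.04 log units; within the scatter), the only readable step at this position. On this read-out, the two groups are not told apart. Compound 2 gives > 50000 nM, a limit and not a number, and the steps to and from it cannot be read.

From the compounds shown here alone, whether an amine or a carboxylic acid in this place would give a step beyond the scatter remains open. Also open, going by these compounds, is how 2-methoxyethoxy compares in number with cyclohexyl or 3-bromophenyl.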